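The source may hold more compounds than are shown below. What is called first, only, known or untested is meant among the compounds shown, and "the series" means these compounds.

Measured in a functional assay on thoracic aorta (Rattus norvegicus, strain Wistar), with a stated time of 15 min; a lower number here means that less compound is needed, a higher number that more compound is needed for the effect:
- compound 1 `CCOc1ccc(F)cc1C(C)NC(=O)NS(=O)(=O)c1ccc(Cl)cc1`: > 300000 nM
- compound 2 `COc1ccc(F)cc1C(C)NC(=O)N(C)S(=O)(=O)c1ccc(Cl)cc1`: 12600 nM

The entry for compound 1 is a limit of the assay, not a number. For the measured compounds named here, compound 2 therefore holds the only true number in this assay. Compound 3 `CCOc1ccc(F)cc1C(C)NC(=O)N(C)S(=O)(=O)c1ccc(Cl)cc1` differs from compound 2 in one place: methyl in place of hydrogen on a saturated chain carbon bound to an oxygen on an aromatic ring, so methoxy becomes ethoxy. Going by the values given here, no measured pair shows this change alone, so no firm direction can be given, and little or no shift beyond the scatter is expected. The expected step of a 1.1-fold higher number from compound 2 to compound 3 (0.05 log units; within the scatter) is small. For compound 3 the estimated value is 14000 nM, with an expected range of 4000 nM to 50000 nM.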

Compound 3, half-maximal effective concentration: 24500 nM
For compound 3 the middle estimate is 1.8-fold (0.24 log units) below the measured one; low and high end bracket the measured number.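

In this assay, methyl in place of hydrogen on a saturated chain carbon bound to an oxygen on an aromatic ring, turning methoxy into ethoxy, gives a 1.9-fold higher number from compound 2 to compound 3 (0.29 log units; within the scatter). Methyl in place of hydrogen on an amide-type nitrogen gives an at least 12-fold lower number from compound 1 to compound 3 (1.08 log units; beyond the scatter), so the nitrogen change counts for far more here than the chain change. Compound 1 carries a limit of the assay, > 300000 nM, so the size of that step is only a bound.

On these data alone, whether a longer chain such as propoxy, or an amine, would fit at this position stays open. The compounds shown also leave open how large the nitrogen step is when methoxy stands in place of ethoxy.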